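Swapping the halogenated phenyl ring on the shared core

The source may report more compounds than this note shows. Statements on the series, on what has been measured and on what is new or still open speak of the compounds shown alone.

Compounds measured so far:
Compound 1 `C=CC(=O)Nc1cccc(NC(=O)CSc2nc(Nc3ccccc3Br)c3ccccc3n2)c1` gives 15200 nM in a functional assay on MDA-MB-231 cells (Homo sapiens) for inhibition, read by MTT assay, with a stated time of 72 h; on this read-out higher numbers stand for weaker inhibition and lower numbers for stronger inhibition.
Compound 2 `C=CC(=O)Nc1cccc(NC(=O)CSc2nc(Nc3cccc(Cl)c3)c3ccccc3n2)c1` gives 16300 nM in this assay.

Compound 2 has the highest of the two numbers, and its nearest neighbour is compound 1 at a 1.1-fold higher number from compound 1 to compound 2 (0.03 log units; within the scatter). Compound 3 `C=CC(=O)Nc1cccc(NC(=O)CSc2nc(Nc3ccc(F)cc3)c3ccccc3n2)c1` differs from compound 2 by 4-fluorophenyl in place of 3-chlorophenyl on a nitrogen on an aromatic ring. For the measured compounds named here, the only step bearing on this, a 1.1-fold higher number from compound 1 to compound 2 (0.03 log units; within the scatter), changed the halogenated phenyl ring and stayed within the scatter, so no step beyond the scatter is expected from compound 2 to compound 3, a 1.0-fold lower number from compound 2 to compound 3 (0.01 log units; within the scatter). Compound 3 is therefore estimated at 16000 nM, with a range from 8000 nM to 32000 nM.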

Compound 3, half-maximal inhibitory concentration: 9490 nM
Beside the measured number, compound 3's estimate is 1.7-fold (0.23 log units) above it; measured number inside the range.
By their numbers in this assay, from the lowest: compounds 3, 1 and 2 (each within the scatter of the next).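

In this assay, 4-fluorophenyl on this nitrogen gives a 1.7-fold lower number from compound 2 to compound 3 (0.23 log units; within the scatter) and a 1.6-fold lower number from compound 1 to compound 3 (0.20 log units; within the scatter). Three phenyl rings that differ in their halogen and its place therefore cannot be told apart here, so this halogen swap has shown no clear effect on the number.

On these data alone, whether a phenyl ring with no halogen, or one carrying an amine or a carboxylic acid, would move the number beyond the scatter remains open. No supporting measurement is available to explain the differences seen among these compounds.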